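The source may hold more compounds than are shown below. What is called first, only, known or untested is meant among the compounds shown, and "the series" means these compounds.

Compound 1 `COc1ccc(C(=O)/C=C/c2ccc(-c3ccccc3)cc2)c2c1C=CC(C)(C)O2` in a functional assay on SW-620 cells (Homo sapiens) for antiproliferative activity, read by MTT assay, with a stated time of 24 h (a higher number here means a weaker inhibitor, a lower number a stronger inhibitor), gives > 10000 nM, which is a limit of the assay.
Compound 2 `COc1ccc(C(=O)/C=C/c2ccc(N3CCCC3)cc2)c2c1C=CC(C)(C)O2` in this assay gives 7150 nM.
Compound 3 `COc1ccc(C(=O)/C=C/c2ccccc2)c2c1C=CC(C)(C)O2` in this assay gives > 10000 nM, again a limit of the assay.

Compound 3 therefore stands only at a limit, as does compound 1, a point noted in the limit of > 10000 nM in this assay, at which 2 of the 3 values shown sit; only compound 2 gives a number. Compound 4 `COc1ccccc1/C=C/C(=O)c1ccc(OC)c2c1OC(C)(C)C=C2` differs from compound 3 by methoxy in place of hydrogen on an aromatic carbon. The steps known so far, a step that the two limits leave unreadable from compound 1 to compound 3 and an at least 1.3-fold higher number from compound 2 to compound 3 (0.14 log units; that floor lies within the scatter), concern other groups on that ring and neither involves methoxy, and the limits leave them small or unreadable. He expects for compound 4 no step beyond the scatter, a step that the limit leaves unreadable from compound 3 to compound 4, and estimates it at 15000 nM, within 5000 nM to 50000 nM, most likely again reported only as a limit.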

Compound 4, half-maximal inhibitory concentration: > 10000 nM
Compound 4 ended at the assay's limit; the forecaster's own chance of this, stated with the estimate: 70%; the middle value is on the limit's open side.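

No step can be read from compound 3 to compound 4, since both stand only at a limit: the limit of > 10000 nM in this assay, at which 3 of the 4 values shown sit.
Going by these compounds, whether methoxy in place of hydrogen changes antiproliferative activity at all, and how compound 1, compound 3 and compound 4 rank, stays open.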